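The source may hold more compounds than are shown below. What is called first, only, known or untested is meant among the compounds shown, and "the series" means these compounds.

Working notes on the series

Among the measured compounds shown here, compound 1 `COc1ccc([C@@H]2CC(=O)c3c(O)cc(OCc4cn(Cc5ccccc5C(F)(F)F)nn4)cc3O2)cc1O` stands lowest of the three numbers so far in a functional assay on RAW264.7 cells (Mus musculus) for inhibition, read by Griess assay, with stated times of 2 h and 24 h (on this read-out higher numbers stand for weaker inhibition and lower numbers for stronger inhibition), where compound 1 gives 12500 nM; both neighbours sit within the scatter of it. Compound 2 `COc1ccc([C@@H]2CC(=O)c3c(O)cc(OCc4cn(Cc5cccc(C#N)c5)nn4)cc3O2)cc1O` gives 18000 nM in this assay, and compound 3 `COc1ccc([C@@H]2CC(=O)c3c(O)cc(OCc4cn(Cc5ccc(C)cc5)nn4)cc3O2)cc1O` gives 16800 nM. The three measured steps are all exchanges of one aryl group for another on a saturated chain carbon bound to an aromatic nitrogen: a 1.4-fold higher number from compound 1 to compound 2 (0.16 log units; within the scatter), a 1.3-fold higher number from compound 1 to compound 3 (0.13 log units; within the scatter) and a 1.1-fold lower number from compound 2 to compound 3 (0.03 log units; within the scatter), none of them beyond the scatter.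

Compound 4 `CCn1cc(COc2cc(O)c3c(c2)O[C@H](c2ccc(OC)c(O)c2)CC3=O)nn1` differs from compound 1 as follows: methyl in place of 2-(trifluoromethyl)phenyl on a saturated chain carbon bound to an aromatic nitrogen. The measured steps bear on it only loosely, since each keeps a six-membered aromatic ring at that position, whereas here the ring is lost altogether. What they do show is that three different aryl groups at this position give numbers indistinguishable within the scatter, so the position itself has not so far moved the read-out. For the measured compounds named here, with no measured step that removes the ring, the expectation for compound 4 is a number near compound 1, possibly somewhat higher; the expected step is a 1.6-fold higher number from compound 1 to compound 4 (0.20 log units; within the scatter). The estimate for compound 4 in this assay is 20000 nM, with an expected range from 8000 nM to 50000 nM.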

Compound 4, half-maximal inhibitory concentration: 15000 nM
Compound 4: the middle estimate sits 1.3-fold (0.12 log units) above what was measured, within the range that was stated.
By their numbers in this assay, from the lowest: compounds 1, 4, 3 and 2 (each within the scatter of the next).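

Losing the ring altogether leaves the number in this assay level with those of the aryl compounds, with a 1.2-fold higher number from compound 1 to compound 4 (0.08 log units; within the scatter) and a 1.1-fold lower number from compound 3 to compound 4 (0.05 log units; within the scatter) and a 1.2-fold lower number from compound 2 to compound 4 (0.08 log units; within the scatter) as the steps in question. The earlier compounds shown here all kept a six-membered aromatic ring at this position, whereas compound 4 shows that the ring is not needed to hold the number at this level: the change from 2-(trifluoromethyl)benzyl to ethyl stays within the scatter. No measurement on hand bears on why this position leaves the read-out unmoved.

From the compounds shown here alone, whether a primary amine, a carboxylic acid or a longer chain such as n-octyl on a saturated chain carbon bound to an aromatic nitrogen would move the number beyond the scatter remains open. Also open, going by these compounds, is whether changes elsewhere on the shared core would move it more than any change seen here.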